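The source may hold more compounds than are shown below. What is called first, only, known or untested is meant among the compounds shown, and "the series" means these compounds.

Three compounds have been measured in a functional assay on CRL2813 cells (Homo sapiens) for cytotoxicity, read by sulforhodamine B assay, with a stated time of 5 days; a higher number here means a weaker inhibitor, a lower number a stronger inhibitor:
compound 1 `O=C(Nc1cccc(C(F)(F)F)c1)N[C@H]1CC[C@H](Oc2cccc(C(F)(F)F)c2)CC1` gives 1300 nM;
compound 2 `O=C(Nc1ccc([N+](=O)[O-])cc1)N[C@H]1CC[C@H](Oc2ccc(F)cc2)CC1` gives 2300 nM;
compound 3 `O=C(Nc1ccccc1)N[C@H]1CC[C@H](Oc2ccc(F)cc2)CC1` gives 20000 nM.

Compound 1 has the lowest of the three numbers; compound 2 lies within the scatter of it, while compound 3 stands well beyond. The only single-point step shown, an 8.7-fold higher number from compound 2 to compound 3 (0.94 log units; beyond the scatter), concerns a change elsewhere in the shared core, not the group on the oxygen on the saturated carbon. Compound 4 `O=C(Nc1cccc(C(F)(F)F)c1)N[C@H]1CC[C@H](Oc2ccc(Cl)cc2)CC1` differs from compound 1 by 4-chlorophenyl in place of 3-(trifluoromethyl)phenyl on an oxygen on a saturated carbon. Among the compounds with values here, no measured step touches that part of the core, so this change is untested here. For compound 4 the expected step is a 1.9-fold higher number from compound 1 to compound 4 (0.28 log units; within the scatter), small and uncertain. Compound 4 is therefore estimated at 2500 nM in this assay, with a range from 800 nM to 8000 nM.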

Compound 4, half-maximal inhibitory concentration: 2000 nM
Estimate against measurement, compound 4: 1.3-fold (0.10 log units) above; the measured number falls inside the stated range.
By their numbers in this assay, from the lowest: compounds 1, 4 and 2 (each within the scatter of the next); then compound 3.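

In this assay, the group on the oxygen on a saturated carbon now has a measured step of its own (a 1.5-fold higher number from compound 1 to compound 4 (0.19 log units; within the scatter)). Exchanging 3-(trifluoromethyl)phenyl for 4-chlorophenyl, with the shared core otherwise unchanged, therefore leaves the number within the scatter for this pair. Nothing measured here offers an explanation for this result.

The compounds shown leave open whether a group without an aromatic ring, such as cyclohexyl or a longer chain, would read alike at this position. They also leave open how a phenyl ring carrying an amine or a carboxylic acid would read there.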